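Working notes: acid analogue of compound 2

The source may report more compounds than this note shows. Statements on the series, on what has been measured and on what is new or still open speak of the compounds shown alone.

Among the compounds with values here, compound 2 `CN1CC[C@H](c2ccc(Cl)cc2)[C@@H](CC(=O)N(C)C)C1` carries the (dimethylcarbamoyl)methyl group on a saturated ring carbon of the shared core; in an assay on Cortex with Norepinephrine transporter (Rattus norvegicus) as the target (a lower number here means a stronger inhibitor, a higher number a weaker inhibitor), compound 2 gives 46 nM, the lowest of the two numbers measured so far. Within the data shown here, the nearest comparator is compound 1 `CN1CC[C@H](c2ccc(Cl)cc2)[C@@H](C(=O)OC(C)(C)C)C1`, which in this assay gives 350 nM; the only step recorded, a 7.6-fold lower number from compound 1 to compound 2 (0.88 log units; beyond the scatter), is modest but beyond the scatter. Compound 3 `CN1CC[C@H](c2ccc(Cl)cc2)[C@@H](CCC(=O)O)C1` differs from compound 2 by carboxymethyl in place of dimethylcarbamoyl on a saturated chain carbon bound to a saturated ring carbon. Among the measured compounds shown here, no measured pair isolates an amide-to-acid exchange, so that single step bears only indirectly, showing that the group at this position shifts the number by a modest amount in either direction. The expectation for compound 3 is therefore a weaker number, a 6.5-fold higher number from compound 2 to compound 3 (0.81 log units; beyond the scatter), carrying wide uncertainty. Compound 3 is estimated at 300 nM, within a range of 60 nM to 1500 nM.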

Compound 3, inhibition constant: 425 nM
Compound 3: middle estimate off by 1.4-fold (0.15 log units), on the low side; low and high end bracket the measured number.
By their numbers in this assay, from the lowest: compound 2; then compounds 1 and 3 (each within the scatter of the next).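

In this assay, within the data shown here, replacing (dimethylcarbamoyl)methyl with 2-carboxyethyl on the saturated ring carbon gives the first measured step between two side chains that both end in a carbonyl group (a 9.2-fold higher number from compound 2 to compound 3 (0.97 log units; beyond the scatter)), so the low number of compound 2 does not carry over to the acid. Against tert-butoxycarbonyl, the acid chain shows no separation beyond the scatter (a 1.2-fold higher number from compound 1 to compound 3 (0.08 log units; within the scatter)), leaving (dimethylcarbamoyl)methyl as the only group here with a number clearly apart from the others. No measurement offered here bears on the reason for either step.

Chain length and end group change together in this pair, so their separate contributions remain unresolved. A carboxylic acid on the shorter chain, as carboxymethyl on the saturated ring carbon, and 2-(dimethylcarbamoyl)ethyl, the amide on the longer chain, would separate them.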